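Oxolan-3-yl in Place of a Fluorinated Chain

This account rests on a few compounds, and the source may have more. Where it says the series, first, only, none or still open, it means among the compounds named here.

Compound 1 `C[C@H](CF)OC(=O)N1CCC(O[C@H]2CC[C@H](Oc3cnc(S(C)(=O)=O)cn3)CC2)CC1`: 115%
Compound 2 `C[C@@H](CF)OC(=O)N1CCC(O[C@H]2CC[C@H](Oc3cnc(S(C)(=O)=O)cn3)CC2)CC1`: 123%

In a functional assay on isolated protein for agonist activity at Glucose-dependent insulinotropic receptor (Rattus norvegicus), read by HTRF and cAMP accumulation (on this read-out higher numbers stand for larger maximal responses and lower numbers for smaller maximal responses), compound 2 gives 123%, and compound 1 gives 115%; the two values lie within the scatter of each other, a number 8 percentage points higher from compound 1 to compound 2 (within the scatter), because of the fact that compounds 1 and 2 differ only in the configuration as drawn. Compound 3 `CS(=O)(=O)c1cnc(O[C@H]2CC[C@H](OC3CCN(C(=O)OC4CCOC4)CC3)CC2)cn1` carries a different change: oxolan-3-yl in place of 1-(fluoromethyl)ethyl on an oxygen next to a carbonyl group. For the measured compounds named here, the one measured step concerns configuration only, so it gives no guidance for this replacement, and no step beyond the scatter is expected, a number 8 percentage points lower from compound 2 to compound 3 (within the scatter). Compound 3 is therefore estimated at 115%, with a range from 95% to 135%.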

Compound 3, largest response reached (Emax), in percent of the reference or control that the assay uses: 109%
For compound 3 the middle estimate is 6 percentage points above the measured one, within the range that was stated.
By their numbers in this assay, from the lowest: compounds 3, 1 and 2 (each within the scatter of the next, the first and the last beyond it).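

In this assay, oxolan-3-yl on an oxygen next to a carbonyl group gives a number 14 percentage points lower from compound 2 to compound 3 (beyond the scatter), yet a number 6 percentage points lower from compound 1 to compound 3 (within the scatter). The same replacement therefore reads as a modest loss against one partner and as no clear change against the other, and the two partners are separated only as follows: the fact that compounds 1 and 2 differ only in the configuration as drawn. A ring can thus take the place of the fluorinated chain here, with compound 3 still at 109%.

Open, going by these compounds, is whether an amine or a longer chain at this place would hold such a response. Also open, on these data alone, is how each single configuration of the oxolan-3-yl group compares.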